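A Third Aryl Variant on the Shared Core

The compounds below may be only part of what the source reports. "The series", "measured", "known", "first", "only" and "open" are said of these compounds alone.

Compound 2 `CCOC(=O)CCCCCOc1cccc(CN(C(=O)c2ccc(-c3cnc(OC)nc3OC)cc2)C(C)C)c1` carries a 2,4-dimethoxypyrimidin-5-yl group on the shared core. In an ADME assay on Raji cells (Homo sapiens) for cytotoxicity, read by CellTiter-Glo and resazurin assay, with a stated time of 72 h (a higher number here means that more compound is needed for the effect, a lower number that less compound is needed), compound 2 gives only a limit of the assay, > 26000 nM, not a number. Its companion compound 1 `CCOC(=O)CCCCCOc1cccc(CN(C(=O)c2ccc(-c3cccc(NC(C)=O)c3)cc2)C(C)C)c1` carries 3-acetamidophenyl at the same place. In this assay compound 1 likewise gives only a limit, > 26000 nM. The step that the two limits leave unreadable from compound 1 to compound 2 cannot be read in either direction because the limit of > 26000 nM in this assay, at which 2 of the 2 values shown sit, applies to both of its ends, so it tells nothing about the size of the change.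

Compound 3 `CCOC(=O)CCCCCOc1cccc(CN(C(=O)c2ccc(-c3cccc(C(C)=O)c3)cc2)C(C)C)c1` has not yet been measured. The change from compound 2 is 3-acetylphenyl in place of 2,4-dimethoxypyrimidin-5-yl on an aromatic carbon. Among the measured compounds shown here, the only measured step is the unreadable one between compound 1 and compound 2, so there is no sized step that bears on the new change. Both measured compounds sit at the limit, and compound 3 is therefore expected to remain there as well, with an expected step that the limit leaves unreadable from compound 2 to compound 3 that is effectively none. The estimate for compound 3 in this assay is 35000 nM, within a range from 12000 nM to 100000 nM.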

Compound 3, half-maximal effective concentration: > 26000 nM
Compound 3: a limit, no number (the forecaster's own chance of this, stated with the estimate: 75%); the middle value is on the limit's open side.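

Compound 3 gives only a limit in this assay, so no new step can be read among compound 1, compound 2 and compound 3, because the same limit sits at both ends of every comparison: the limit of > 26000 nM in this assay, at which 3 of the 3 values shown sit.

The compounds shown leave open whether any group at this place on the shared core would give a number rather than a limit in this assay.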